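Removing the Chloro Group From Compound 3

The source may report more compounds than this note shows. Statements on the series, on what has been measured and on what is new or still open speak of the compounds shown alone.

Of the compounds shown here, three built on one shared core have been tested in a functional assay on K562 cells (Homo sapiens) for cytotoxicity, read by MTT assay, with a stated time of 72 h; a lower number here means a stronger inhibitor, a higher number a weaker inhibitor. Compound 3 `C#CCn1cc(C(=O)NC(CC(=O)Nc2ccccc2)c2ccccc2)c(=O)c2ccc(Cl)nc21` gives 7700 nM in this assay. Compound 1 `C#CCn1cc(C(=O)NC(CC(=O)Nc2ccccc2)c2ccccc2)c(=O)c2cc(F)c(Cl)nc21` gives 6600 nM, and compound 2 `C#CCn1cc(C(=O)NC(CC(=O)Nc2ccccn2)c2ccccc2)c(=O)c2ccc(Cl)nc21` gives 5900 nM. Compound 3 does not separate from either neighbour: the steps of a 1.2-fold higher number from compound 1 to compound 3 (0.07 log units; within the scatter) and a 1.3-fold higher number from compound 2 to compound 3 (0.12 log units; within the scatter) both stay within the scatter, so the three numbers are, for practical purposes, indistinguishable.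

Compound 4 `C#CCn1cc(C(=O)NC(CC(=O)Nc2ccccc2)c2ccccc2)c(=O)c2cccnc21` has not yet been measured. It differs from compound 3 by hydrogen in place of chloro on an aromatic carbon. Of the measured steps, the one that bears most directly on this change is the swap of fluoro for hydrogen on the same ring between compound 1 and compound 3, which moved the number only within the scatter. The other measured step concerns a different part of the molecule and offers little guidance. Compound 4 is therefore expected to sit close to compound 3, with an estimated step of a 1.0-fold higher number from compound 3 to compound 4 (0.02 log units; within the scatter), not beyond the scatter. The estimate for compound 4 in this assay is 8000 nM, with a range from 4000 nM to 16000 nM.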

Compound 4, half-maximal inhibitory concentration: > 10000 nM
Compound 4: no number, only a limit; the forecaster's own chance of this, stated with the estimate: 5%; middle value at least 1.2-fold (0.09 log units) away from the limit.
By their numbers in this assay, from the lowest: compounds 2, 1 and 3 (each within the scatter of the next). At a limit, above all of these: compound 4.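

In this assay compound 4 gives a limit and not a number, and it is the only one of the four to do so: the limit of > 10000 nM in this assay, at which 1 of the 4 values shown sits.

Hydrogen in place of chloro, on the aromatic carbon next to the ring nitrogen, gives an at least 1.2-fold higher number from compound 3 to compound 4 (0.11 log units; that floor lies within the scatter), so this change has a floor and no upper end, and it cannot be said to go beyond the scatter. Among these compounds, the earlier steps, at the fluoro on the same ring and at the pyridin-2-yl on the amide-type nitrogen, all kept the chloro and all ended in readable numbers, so this position is the first to show a step whose full size is unknown.

The compounds shown leave open how far compound 4 truly lies from compound 3. They also leave open whether an amine or a bromo group in place of the chloro would give a readable number or would reach the limit too.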